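A Fluoro Substituent Added to Compound 2

The compounds below may be only part of what the source reports. "The series", "measured", "known", "first", "only" and "open" are said of these compounds alone.

compound 1 `O=C1NC(=O)C(c2ccc(-c3ccc4ccccc4c3)[nH]c2=O)O1` 200 nM
compound 2 `CC(C)C1(c2ccc(-c3ccc4ccccc4c3)[nH]c2=O)OC(=O)NC1=O` 10 nM

Both compounds were tested in a functional assay on U2OS cells for antagonist activity at prostaglandin E2 receptor EP3 subtype (Homo sapiens), read by FLIPR and calcium flux, with a stated time of 24 h; on this read-out higher numbers stand for weaker inhibition and lower numbers for stronger inhibition. Compound 2 gives the lowest of the two numbers; its nearest neighbour is compound 1, and the step of a 20-fold lower number from compound 1 to compound 2 (1.30 log units; beyond the scatter) leaves compound 2 standing clearly apart. Compound 3 `CC(C)C1(c2ccc(-c3ccc4cccc(F)c4c3)[nH]c2=O)OC(=O)NC1=O` has not yet been measured. It differs from compound 2 by fluoro in place of hydrogen on an aromatic carbon. Within the data shown here, no measured step bears on this change: the only step in the set, a 20-fold lower number from compound 1 to compound 2 (1.30 log units; beyond the scatter), concerns the saturated ring carbon and carries no information about a fluoro group on the aromatic ring. With nothing to draw on, a change no larger than the scatter is expected in this assay, in either direction. Compound 3 is therefore estimated at 10 nM, with a range from 4 nM to 25 nM. The step of no change at the digits printed from compound 2 to compound 3 (within the scatter) that this estimate implies is expected to lie within the scatter.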

Compound 3, inhibition constant: 3.16 nM
For compound 3 the middle estimate is 3.2-fold (0.50 log units) above the measured one; the measured number lies below the stated range.
By their numbers in this assay, from the lowest: compound 3; then compound 2; then compound 1.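

Fluoro in place of hydrogen on an aromatic carbon, ortho to a fused ring and meta to a fused ring, gives a 3.2-fold lower number from compound 2 to compound 3 (0.50 log units; beyond the scatter) in this assay. Among these compounds, the only earlier step concerned the saturated ring carbon, so this is the first sign that the number also responds to a change on the aromatic ring system, and that a single fluoro at this carbon goes with stronger inhibition, not weaker. Nothing available explains why this step goes the way it does.

The compounds shown leave open whether chloro, methyl or methoxy on the same aromatic carbon would move the number as fluoro does. They also leave open whether fluoro would have the same effect on the core of compound 1, which carries hydrogen in place of isopropyl.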